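The source may hold more compounds than are shown below. What is called first, only, known or untested is meant among the compounds shown, and "the series" means these compounds.

Among the compounds with values here, compound 2 `Cc1cc(NCc2ccccn2)n2ncc(-c3ccco3)c2n1` is the one compound in this set with a measured number: in a physicochemical assay for solubility, read by HPLC, using the shake flask method, measured as kinetic solubility, with a stated time of 2 h, at pH 7.4 (on this read-out higher numbers stand for higher solubility and lower numbers for lower solubility), compound 2 gives 48800 nM. Compound 1 `Cc1cc(NCc2ccccn2)n2ncc(-c3ccccc3C)c2n1` carries 2-methylphenyl on the same aromatic carbon of the shared core, and in this assay compound 1 gives < 5000 nM, which is a limit of the assay and not a number. Within the data shown here, the one measured step, an at least 9.7-fold higher number from compound 1 to compound 2 (0.98 log units; beyond the scatter), is therefore known only as a floor, since it starts from a value that sits at the limit of < 5000 nM in this assay, at which 1 of the 2 values shown sits.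

Compound 3 `Cc1cc(NCc2ccccn2)n2ncc(-c3ccn(C)n3)c2n1` differs from compound 2 by 1-methyl-1H-pyrazol-3-yl in place of furan-2-yl on an aromatic carbon. Among the measured compounds shown here, no measured step in this set swaps one five-membered aromatic ring for another; the only step swaps a six-membered ring for a five-membered one, and it went upward. With the entering ring holding one more hetero atom and one more hydrogen-bond acceptor than the leaving one, a small rise is expected, a 1.6-fold higher number from compound 2 to compound 3 (0.21 log units; within the scatter), though a step of this size could still fall within the scatter. In this assay compound 3 is expected to give about 80000 nM, with a range from 30000 nM to 200000 nM.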

Compound 3, solubility: 188000 nM
For compound 3 the middle estimate is 2.4-fold (0.37 log units) below the measured one, and the stated range covers the measured number.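

Within the data shown here, this is the first step in this assay that swaps one five-membered aromatic ring for another on this aromatic carbon, and it gives a 3.9-fold higher number from compound 2 to compound 3 (0.59 log units; beyond the scatter). The position therefore still tells groups apart after the six-membered ring has gone: 1-methyl-1H-pyrazol-3-yl and furan-2-yl are both single five-membered aromatic rings with no net charge and no hydrogen-bond donors, yet they differ beyond the scatter. Set against 2-methylphenyl, the change reads an at least 37-fold higher number from compound 1 to compound 3 (1.57 log units; beyond the scatter), and this size is only a floor, since compound 1 gives a limit of the assay and not a number: the limit of < 5000 nM in this assay, at which 1 of the 3 values shown sits.

The compounds shown leave open which part of the change goes with the higher number, as the two ring nitrogens replace the ring oxygen and the methyl group arrives in the same step. Also open, as far as these compounds go, is whether a group other than an aromatic ring on this carbon, such as an amine or a carboxylic acid, would raise the number further or lower it.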